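Working notes: from compound 2 to compound 3

The source may hold more compounds than are shown below. What is called first, only, known or untested is meant among the compounds shown, and "the series" means these compounds.

Measured in a functional assay on A549 cells (Homo sapiens) for antiproliferative activity, read by MTT assay, with a stated time of 72 h; on this read-out higher numbers stand for weaker inhibition and lower numbers for stronger inhibition:
compound 1 `COc1cc2c(Nc3ccc(C#N)cc3)ncnc2cc1OCCCN1CCC(CO)CC1`: > 100000 nM (a limit)
compound 2 `COc1cc2c(Nc3ccc(C#N)cc3)ncnc2cc1OCCCN1CCC(N2CCCCC2)CC1`: 30700 nM

Compound 1 gives only a limit (> 100000 nM). For the measured compounds named here, compound 2 therefore holds the only actual number so far (30700 nM). The next compound is compound 3 `COc1cc2c(Nc3ccc(C#N)cc3)ncnc2cc1OCCCN1CCN(C)CC1`, with 4-methylpiperazin-1-yl in place of 4-(piperidin-1-yl)piperidin-1-yl on a saturated chain carbon, three bonds along the chain from an oxygen on an aromatic ring.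

Going by the values given here, one measured step bears on this change. It is an at least 3.2-fold lower number from compound 1 to compound 2 (0.51 log units; beyond the scatter), with piperidin-1-yl in place of hydroxymethyl on a saturated ring carbon. Compound 3 no longer carries that piperidin-1-yl, so a modest move toward a higher number, meaning weaker inhibition, is expected. The expected step is a 1.6-fold higher number from compound 2 to compound 3 (0.21 log units; within the scatter), an estimate resting on this single comparison. In this assay the estimate for compound 3 is 50000 nM, with an expected range of 20000 nM to 120000 nM.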

Compound 3, half-maximal inhibitory concentration: 48800 nM
Estimate against measurement, compound 3: 1.0-fold (0.01 log units) above; low and high end bracket the measured number.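

Replacing 4-(piperidin-1-yl)piperidin-1-yl, with its two rings, by the smaller 4-methylpiperazin-1-yl gives a 1.6-fold higher number from compound 2 to compound 3 (0.20 log units; within the scatter), so in this assay this place on the chain tolerates the loss of one ring without a change that can be told from scatter. Putting 4-methylpiperazin-1-yl in place of 4-(hydroxymethyl)piperidin-1-yl gives an at least 2.0-fold lower number from compound 1 to compound 3 (0.31 log units; beyond the scatter), so a group with a second ring nitrogen also separates from compound 1 without the extra piperidine ring of compound 2. That step rests on a limit of the assay and not on a number: the limit of > 100000 nM in this assay, at which 1 of the 3 values shown sits.

On these data alone, the true size of both steps from compound 1 stays unknown. Also open, as far as these compounds go, is whether a morpholine or a dimethylamino group at this place, or a shorter chain carrying 4-methylpiperazin-1-yl, would move the number beyond the scatter.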